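Chalcone-bearing series: move from compound 3 to compound 4

The source may hold more compounds than are shown below. What is called first, only, known or untested is meant among the compounds shown, and "the series" means these compounds.

Measured so far:
compound 1 `COc1cc(/C=C/C(=O)c2cc(-c3cc(OC)c(OC)c(OC)c3)n3nc(-c4ccccc4)cc3n2)cc(OC)c1OC` — 25900 nM
compound 2 `COc1ccc(-c2cc(/C=C/C(=O)c3ccc(OC)c(OC)c3)nc3cc(-c4ccccc4)nn23)cc1` — 7400 nM
compound 3 `COc1ccc(C(=O)/C=C/c2cc(-c3ccc(OC)c(OC)c3)n3nc(-c4ccccc4)cc3n2)cc1` — 11900 nM

Among the measured compounds shown here, of the three numbers so far in a functional assay on A549 cells (Homo sapiens) for antiproliferative activity, read by MTT assay, with a stated time of 24 h (a lower number here means a stronger inhibitor, a higher number a weaker inhibitor), compound 3 stands second highest. Its nearest neighbour is compound 2, whose value lies within the scatter of that of compound 3, so the two cannot be ordered. Compound 1 lies beyond the scatter on the higher side, with compound 3 giving the lower number of that pair.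

Compound 4 `COc1ccc(-c2cc(C(=O)/C=C/c3ccc(Cl)cc3)nc3cc(-c4ccccc4)nn23)cc1OC` is not yet measured. Compared with compound 3 the change is (2-(4-chlorophenyl)ethenyl)carbonyl in place of 2-((4-methoxyphenyl)carbonyl)ethenyl on an aromatic carbon. For the measured compounds named here, no pair of measured compounds differs in one place, so no single step between them is available to guide the expectation; the three values span a modest range overall, and none of them rests on a change of this kind.

Compound 4 is estimated at 10000 nM, with a range from 3000 nM to 35000 nM. The step of a 1.2-fold lower number from compound 3 to compound 4 (0.08 log units; within the scatter) is expected to be no larger than the scatter, in either direction, since the measured compounds give no reason to expect more.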

Compound 4, half-maximal inhibitory concentration: 22000 nM
Beside the measured number, compound 4's estimate is 2.2-fold (0.34 log units) below it, within the range that was stated.
By their numbers in this assay, from the lowest: compounds 2, 3, 4 and 1 (each within the scatter of the next, the first and the last beyond it).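

In this assay, among the compounds shown here, the exchange on the aromatic carbon next to the ring nitrogen gives a 1.8-fold higher number from compound 3 to compound 4 (0.27 log units; within the scatter) and so provides the first one-place step, with no readable difference across it. The step joins two alterations: the carbonyl now stands on the ring with the ethenyl outward, where the ethenyl stood on the ring before, and a 4-chlorophenyl end replaces a 4-methoxyphenyl end. No measurement offered here accounts for the result.

For the compounds shown here, whether either alteration alone would leave the number within the scatter remains open, as the single step cannot separate them. Also open, on these data alone, is how a dimethylamino group or a carboxylic acid in place of the chlorine on that phenyl ring would read.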